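The source may report more compounds than this note shows. Statements on the series, on what has been measured and on what is new or still open speak of the compounds shown alone.

Compound 2 `CC(=O)Oc1ccc(N2C(=O)/C(=C/N3N=C(c4ccccc4)CC3c3ccccc3O)SC2=S)cc1` gives 9400 nM in a functional assay on HL-60 cells (Homo sapiens) for antiproliferative activity, read by MTT assay, with a stated time of 72 h (a lower number here means a stronger inhibitor, a higher number a weaker inhibitor), the highest of the three numbers measured. Compound 1 `CC(=O)Oc1cccc(N2C(=O)/C(=C/N3N=C(c4ccccc4)CC3c3ccccc3O)SC2=S)c1` gives 118 nM, and compound 3 `O=C1/C(=C/N2N=C(c3ccccc3)CC2c2ccccc2O)SC(=S)N1c1cccnc1` gives 720 nM. Compound 4 `O=C1/C(=C/N2N=C(c3ccccc3)CC2c2ccccc2O)SC(=S)N1c1cccc(C(F)(F)F)c1` differs from compound 2 as follows: 3-(trifluoromethyl)phenyl in place of 4-acetoxyphenyl on an amide-type nitrogen in a ring. Among the compounds with values here, two measured steps bear on this change: an 80-fold higher number from compound 1 to compound 2 (1.90 log units; beyond the scatter) and a 13-fold lower number from compound 2 to compound 3 (1.12 log units; beyond the scatter). Both show that replacing or relocating the 4-acetoxyphenyl on the ring nitrogen lowers the number substantially, and the 3-acetoxyphenyl of compound 1 sits furthest below. As the 3-(trifluoromethyl)phenyl of compound 4 shares that arrangement with compound 1, a large decrease in this assay is expected. Compound 4 is therefore estimated at 300 nM, within 60 nM to 1500 nM, an expected step of a 31-fold lower number from compound 2 to compound 4 (1.50 log units; beyond the scatter).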

Compound 4, half-maximal inhibitory concentration: > 10000 nM
Compound 4: only a limit was reported; the forecaster's own chance of this, stated with the estimate: 5%; at least 33-fold (1.52 log units) between middle value and limit.
By their numbers in this assay, from the lowest: compound 1; then compound 3; then compound 2. At a limit, above all of these: compound 4.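

Compound 4 reads only as a limit in this assay: the limit of > 10000 nM in this assay, at which 1 of the 4 values shown sits. The 3-(trifluoromethyl)phenyl of compound 4 does not bring the low number of compound 1: trifluoromethyl in place of acetoxy gives an at least 84-fold higher number from compound 1 to compound 4 (1.92 log units; beyond the scatter), and 3-(trifluoromethyl)phenyl in place of pyridin-3-yl gives an at least 13-fold higher number from compound 3 to compound 4 (1.14 log units; beyond the scatter). 3-(Trifluoromethyl)phenyl in place of 4-acetoxyphenyl gives an at least 1.0-fold higher number from compound 2 to compound 4 (0.02 log units; that floor lies within the scatter), and that floor lies within the scatter.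

The compounds shown leave open whether the low number of compound 1 needs the acetoxy group itself. A 3-hydroxyphenyl or 3-aminophenyl on the amide-type nitrogen would test this.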